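The source may report more compounds than this note shows. Statements on the series, on what has been measured and on what is new or still open speak of the compounds shown alone.

Measured in a physicochemical assay for lipophilicity; on this read-out higher numbers stand for higher lipophilicity and lower numbers for lower lipophilicity:
- compound 1 `CC(C)n1ccc(NC(=O)c2cc(Oc3ccc(C(=O)N4CCC4)cc3)cc(O[C@@H](C)CO)c2)n1` gives 2.8
- compound 2 `COC[C@H](C)Oc1cc(Oc2cnc(C(=O)N3CCC3)cn2)cc(C(=O)Nc2cnc(C)cn2)c1` gives 2.4
- compound 3 `CC(C)Oc1cc(Oc2ccc(C(=O)N3CCC3)cc2)cc(C(=O)Nc2ccn(C)n2)c1` gives 3.3

Compound 1 stands second highest of the three, beyond the scatter from both compound 2 and compound 3. Compound 4 `Cc1cnc(NC(=O)c2cc(Oc3ccc(C(=O)N4CCC4)cc3)cc(O[C@@H](C)CO)c2)cn1` carries 5-methylpyrazin-2-yl in place of 1-isopropyl-1H-pyrazol-3-yl on an amide-type nitrogen. Going by the values given here, no measured pair isolates this change. Compound 2 has the same 5-methylpyrazin-2-yl on an amide-type nitrogen and reads 2.4, but it also differs from compound 1 elsewhere, so it is only a loose guide. In this assay a fall is expected, with the estimated a number 0.40 log units lower from compound 1 to compound 4 (beyond the scatter) lying slightly beyond the scatter . For compound 4 the estimated value is 2.4, with an expected range of 2 to 2.8.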

Compound 4, distribution coefficient: 2.4
Beside the measured number, compound 4's estimate shows no gap at the digits printed, within the range that was stated.
By their numbers in this assay, from the lowest: compounds 2 and 4 (each within the scatter of the next); then compound 1; then compound 3.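

In this assay the amide-type nitrogen now has its first clean reading, a number 0.40 log units lower from compound 1 to compound 4 (beyond the scatter), with the rest of the molecule unchanged. The exchange of 1-isopropyl-1H-pyrazol-3-yl for 5-methylpyrazin-2-yl thus moves this read-out on its own, which compound 2 and compound 3 could not show, as each differs from compound 1 in more than one place. Nothing at hand gives a cause for this step. The ring and its substituent change together here, so their shares cannot be separated. On these data alone, how a plain pyridin-2-yl on the same nitrogen would read remains open.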